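Aryl change on the shared core: compound 3 to compound 4

The compounds below may be only part of what the source reports. "The series", "measured", "known", "first", "only" and "open" are said of these compounds alone.

In a functional assay on MDA-MB-468 cells (Homo sapiens) for cytotoxicity, read by MTT assay, with a stated time of 96 h (on this read-out higher numbers stand for weaker inhibition and lower numbers for stronger inhibition), compound 1 (`CCc1ccc(-c2ccc(-c3ccc(C(=N)N)cc3)o2)cc1`) reads 3300 nM and compound 2 (`N=C(N)c1ccc(-c2ccc(-c3cccc([N+](=O)[O-])c3)o2)cc1`) reads 3300 nM while compound 3 (`Cc1ccc(-c2ccc(-c3ccc(C(=N)N)cc3)o2)cc1`) reads 3700 nM on the same scale. Compound 3 thus stands within the scatter of both others, and the three numbers do not separate. The move to compound 4 (`N=C(N)c1ccc(-c2ccc(-c3cccc(F)c3)o2)cc1`) is summed up as 3-fluorophenyl in place of 4-methylphenyl on an aromatic carbon and amounts to 3-fluorophenyl in place of 4-methylphenyl on an aromatic carbon, next to the ring oxygen of a five-membered aromatic ring with 1 oxygen. Within the data shown here, the only measured step is a 1.1-fold higher number from compound 1 to compound 3 (0.05 log units; within the scatter) and it concerns hydrogen in place of methyl on a saturated chain carbon, so no measured step covers this exact change. On that step, and with compound 2 at 3300 nM in the same narrow band, no step beyond the scatter is expected. The size estimated in this assay is a 1.1-fold lower number from compound 3 to compound 4 (0.04 log units; within the scatter) with no firm direction. Compound 4 is estimated at 3400 nM with an expected range from 1600 nM to 7000 nM in this series.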

Compound 4, half-maximal inhibitory concentration: 2400 nM
Estimate against measurement, compound 4: 1.4-fold (0.15 log units) above; the measured number falls inside the stated range.
By their numbers in this assay, from the lowest: compounds 4, 1, 2 and 3 (each within the scatter of the next).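

In this assay the replacement of 4-methylphenyl by 3-fluorophenyl on the aromatic carbon next to the ring oxygen gives a 1.5-fold lower number from compound 3 to compound 4 (0.19 log units; within the scatter) and thus stays within the scatter, although it alters both the substituent and where it sits on the phenyl ring. Fluoro in place of nitro on an aromatic carbon gives a 1.4-fold lower number from compound 2 to compound 4 (0.14 log units; within the scatter) and also stays within the scatter, so this position now has two direct aryl comparisons where the earlier compounds offered only a step on the saturated chain. No supporting data bear on these small differences.

The step from compound 3 to compound 4 does not separate the change of substituent from the change of its location, which 3-methylphenyl or 4-fluorophenyl would address. Going by these compounds, whether an amine or a carboxylic acid on the phenyl ring would leave this narrow band remains open.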